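Swapping a carboxy group for a tetrazolylmethyl arm

A few compounds are considered here, and "the series" means these few. Any claim that something is new, unique, unknown or untested is made for them only; others in the source may bear on it.

Compound 1 `O=C(O)c1ccc(COc2cccc(OCc3ccc4ccccc4n3)c2)cc1` was measured in an assay on isolated protein for binding affinity to cysteinyl leukotriene receptor 1 (Cavia porcellus) (a lower number here means a stronger inhibitor, a higher number a weaker inhibitor), and gives 90 nM. Of the two numbers recorded so far this is the higher one: compound 2 `c1cc(OCc2ccc3ccccc3n2)cc(OCc2ccccc2-c2nn[nH]n2)c1`, which carries a tetrazole ring attached directly to one of its benzene rings, gives 20 nM in this assay, a gap that lies beyond the usual scatter of repeat measurements. For the measured compounds named here, no pair of compounds differing in only one place has been measured, so no single change has yet been linked to a known shift in the numbers.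

Compound 3 `c1cc(OCc2ccc(Cc3nnn[nH]3)cc2)cc(OCc2ccc3ccccc3n2)c1` is the next compound to be tested. It is built from compound 1 by one change, ((1H-tetrazol-5-yl)methyl in place of carboxy on an aromatic carbon). The carboxy group is thus replaced by a five-membered ring with four nitrogen atoms, joined through one extra carbon, and the place on the ring stays the same.

Going by the values given here, with no measured step of this kind available, the estimate rests on the two values above. Compound 3 is expected to give a number close to that of compound 1, perhaps somewhat lower, with a 1.5-fold lower number from compound 1 to compound 3 (0.18 log units; within the scatter) as the estimated step; the expected value for compound 3 is 60 nM, within a range from 15 nM to 250 nM.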

Compound 3, inhibition constant: 7.3 nM
For compound 3 the middle estimate is 8.2-fold (0.91 log units) above the measured one, and the stated range ends above it.
By their numbers in this assay, from the lowest: compound 3; then compound 2; then compound 1.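

For the compounds shown here, the swap from compound 1 to compound 3 is the first comparison here that changes only one place, and it shows that this place, on an aromatic carbon para to a large group, strongly affects the result: in this assay, putting (1H-tetrazol-5-yl)methyl in place of carboxy gives a 12-fold lower number from compound 1 to compound 3 (1.09 log units; beyond the scatter) and counts as a large step. Carboxy is therefore not needed at this place for a low number, and the larger group, with its five-membered aromatic ring and its extra carbon, is accepted on the same core. Going by these compounds alone, nothing measured so far explains the step, and it cannot yet be assigned to the ring, to the extra carbon or to any other feature of the new group.

Going by these compounds, the swap changes the ring and the length of the arm together, so it remains open whether a 1H-tetrazol-5-yl group joined directly at this place, or a carboxymethyl group, would give a similar fall. Also open, on these data alone, is whether a longer chain, such as a 2-(1H-tetrazol-5-yl)ethyl arm, would lower the number further or raise it again.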